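Dihydroxyphenyl in Place of Difluorophenyl: What Compound 4 May Give

This account rests on a few compounds, and the source may have more. Where it says the series, first, only, none or still open, it means among the compounds named here.

Of the compounds shown here, three built on one shared core have been measured in a functional assay on HT-29 cells (Homo sapiens) for inhibition, read by MTT assay, with a stated time of 48 h; a lower number here means a stronger inhibitor, a higher number a weaker inhibitor. Compound 1 `COc1cc(/C=C/c2ccc(NC(=O)/C=C/c3ccc(F)cc3)cc2)cc(OC)c1` gives 11600 nM, compound 2 `COc1cc(/C=C/c2ccc(NC(=O)/C=C/c3ccccc3F)cc2)cc(OC)c1` gives 2820 nM, and compound 3 `COc1cc(/C=C/c2ccc(NC(=O)/C=C/c3ccc(F)cc3F)cc2)cc(OC)c1` gives 18100 nM. Compound 3 carries the highest number of the three; compound 1 sits nearest to it, within the scatter, while compound 2 lies furthest away. The measured steps show how fluorine on the terminal ring moves this assay: a 4.1-fold lower number from compound 1 to compound 2 (0.61 log units; beyond the scatter), a 6.4-fold higher number from compound 2 to compound 3 (0.81 log units; beyond the scatter), and a 1.6-fold higher number from compound 1 to compound 3 (0.19 log units; within the scatter). Compound 4 `COc1cc(/C=C/c2ccc(NC(=O)/C=C/c3ccc(O)c(O)c3)cc2)cc(OC)c1` differs from compound 3 by 3,4-dihydroxyphenyl in place of 2,4-difluorophenyl on a double-bonded chain carbon bound to a double-bonded chain carbon. For the measured compounds named here, no measured step involves a hydroxyl group, so the three steps bear on this change only by showing that substituents on this ring shift the number by modest steps in either direction. The estimate therefore stays close to compound 3 with a wide range. Compound 4 is expected to give 10000 nM, between 2500 nM and 40000 nM, in this assay. The expected step is a 1.8-fold lower number from compound 3 to compound 4 (0.26 log units; within the scatter), a modest lowering of the number.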

Compound 4, half-maximal inhibitory concentration: 1560 nM
The estimate for compound 4 lay 6.4-fold (0.81 log units) above the measured number; measured number outside the range, below it.
By their numbers in this assay, from the lowest: compounds 4 and 2 (each within the scatter of the next); then compounds 1 and 3 (each within the scatter of the next).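

In this assay, putting 3,4-dihydroxyphenyl in place of 2,4-difluorophenyl gives a 12-fold lower number from compound 3 to compound 4 (1.06 log units; beyond the scatter), showing that this position also accepts a ring with no fluorine, carrying 2 hydrogen-bond donors and 2 hydrogen-bond acceptors by the computed count. The same group gives a 7.4-fold lower number from compound 1 to compound 4 (0.87 log units; beyond the scatter), while a 1.8-fold lower number from compound 2 to compound 4 (0.26 log units; within the scatter) stays within the scatter, so the 3,4-dihydroxyphenyl and 2-fluorophenyl rings cannot be told apart at this position. For the compounds shown here, no supporting measurement bears on why this change moves the number so far.

The compounds shown leave open whether both hydroxyl groups are needed, as they appear only together in compound 4. They also leave open how a phenyl ring bearing a single hydroxyl, two methoxy groups or an amine would read in this assay.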